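Trimming a methyl on two related cores

This account rests on a few compounds, and the source may have more. Where it says the series, first, only, none or still open, it means among the compounds named here.

Measured so far:
Compound 1, `C=C(CC)C(=O)c1ccc(OCc2nc(-c3ccc([N+](=O)[O-])cc3)cs2)c(C)c1C`, gives 3600 nM.
Compound 2, `C=C(C)C(=O)c1ccc(OCc2nc(-c3ccc([N+](=O)[O-])cc3)cs2)c(C)c1C`, gives 5100 nM.
Compound 3, `C=C(CC)C(=O)c1ccc(OCc2nc(-c3ccc([N+](=O)[O-])cc3)cs2)cc1Cl`, gives 800 nM.

All three numbers come from a functional assay on HL-60 cells (Homo sapiens) for inhibition, read by trypan blue exclusion, with a stated time of 72 h; on this read-out lower numbers stand for stronger inhibition of growth and higher numbers for weaker inhibition of growth. Compound 1 and compound 2 share one core and differ only by hydrogen in place of methyl on a saturated chain carbon bound to a double-bonded chain carbon. That change made a step of a 1.4-fold higher number from compound 1 to compound 2 (0.15 log units; within the scatter), so the two compounds cannot be told apart on this read-out.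

Compound 3 sits on a second core. How that core differs from the core of compound 1 is not broken down here. In this assay compound 3 gives 800 nM, the lowest number of the three, and both other compounds stand clearly apart from it.

Compound 4, `C=C(C)C(=O)c1ccc(OCc2nc(-c3ccc([N+](=O)[O-])cc3)cs2)cc1Cl`, has not yet been measured. It differs from compound 3 by hydrogen in place of methyl on a saturated chain carbon bound to a double-bonded chain carbon. The place of this change is the same, word for word, as the place of the change between compound 1 and compound 2, so it is the same change carried onto the second core. Going by the values given here, the only guide for its size is the step from compound 1 to compound 2, which was small. The step from compound 3 to compound 4 is therefore expected to be a 1.4-fold higher number from compound 3 to compound 4 (0.14 log units; within the scatter), resting on the earlier step of a 1.4-fold higher number from compound 1 to compound 2 (0.15 log units; within the scatter). Compound 4 is accordingly estimated at 1100 nM in this assay, with a plausible range from 500 nM to 2500 nM.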

Compound 4, concentration for 50% growth inhibition: 5900 nM
Compound 4: the middle estimate sits 5.4-fold (0.73 log units) below what was measured; measured number outside the range, above it.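

In this assay, trimming ethyl to methyl on the second core gave a 7.4-fold higher number from compound 3 to compound 4 (0.87 log units; beyond the scatter), a clear loss of growth inhibition, whereas the same trim on the first core left no difference that could be read. A step measured on one core therefore cannot simply be carried over to another core in this series, since the same change gave steps of clearly different size on the two cores: the same change on two cores in this assay, a 1.4-fold higher number (0.15 log units; within the scatter) from compound 1 to compound 2 and a 7.4-fold higher number (0.87 log units; beyond the scatter) from compound 3 to compound 4, 5.2-fold (0.72 log units) apart, beyond the scatter of two such steps. This rests on just two matched pairs, so it does not show which feature of the second core goes with the larger step, why the two steps differ, or how the change would behave on any third core.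

The compounds shown carry only ethyl or methyl at the site of the change, so it remains open whether a longer chain such as propyl, or a ring such as cyclopropyl, would keep the growth inhibition of compound 3 or lose it as compound 4 does. From the compounds shown here alone, it also remains open whether a core with bromine in place of the chlorine of compound 3 would respond to the trim like the first core, like the second, or in neither way.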